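The source may report more compounds than this note shows. Statements on the series, on what has been measured and on what is new or still open speak of the compounds shown alone.

Values in an assay on isolated protein for displacement of a labelled ligand from metabotropic glutamate receptor 5 (Homo sapiens), with a stated time of 60 min, tested at 1 uM (on this read-out higher numbers stand for more inhibition at the one concentration tested (going by the name of the read-out) and lower numbers for less inhibition), for the measured members of the series:

Compound 1 `CC1CCN(c2c(S(=O)(=O)c3cc(Cl)cc(Cl)c3)cnc3ccc(Cl)cc23)CC1`: 88%
Compound 2 `CC1CCN(c2c(S(=O)(=O)c3ccc(F)cc3)cnc3ccc(Cl)cc23)CC1`: 89%
Compound 3 `CC1CCN(c2c(S(=O)(=O)c3ccc(F)cc3)cnc3cc(Cl)ccc23)CC1`: 91%

All three values lie within the scatter of one another, so none of the three can be set apart on this read-out. Compound 2 and compound 3 share the same atoms joined differently; the difference between the two cores is not broken down here, and their two values show nothing beyond scatter.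

One change is made twice in the set. From compound 2 to compound 1 the change is 3,5-dichlorophenyl in place of 4-fluorophenyl on a sulfonyl sulfur and the step is a number 1 percentage points lower from compound 2 to compound 1 (within the scatter). Compound 4 `CC1CCN(c2c(S(=O)(=O)c3cc(Cl)cc(Cl)c3)cnc3cc(Cl)ccc23)CC1` is the unmeasured member; it differs from compound 3 by 3,5-dichlorophenyl in place of 4-fluorophenyl on a sulfonyl sulfur. The place lines are the same word for word, so this is the same change as the one already measured.

For compound 4 the step from compound 3 is expected to be a number 1 percentage points lower from compound 3 to compound 4 (within the scatter), beside the measured one, resting on compound 2 to compound 1 giving a number 1 percentage points lower from compound 2 to compound 1 (within the scatter). Compound 4 is therefore estimated at 90%, with a range of 82% to 96%.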

Compound 4, a percentage reported as inhibition, at one concentration (the size of the read-out at that concentration, not a potency): 93%
For compound 4 the middle estimate is 3 percentage points below the measured one; low and high end bracket the measured number.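

In this assay, 3,5-dichlorophenyl in place of 4-fluorophenyl on a sulfonyl sulfur gives a number 2 percentage points higher from compound 3 to compound 4 (within the scatter). Set beside the earlier step on the other core, the new step does not differ from it: the same change on two cores in this assay, a number 1 percentage points lower (within the scatter) from compound 2 to compound 1 and a number 2 percentage points higher (within the scatter) from compound 3 to compound 4, 3 percentage points apart, within the scatter of two such steps. The change therefore carries across these two cores without a readable difference, but a single tested concentration gives no potency, so this shows neither that the change leaves potency untouched nor that the agreement would hold on a further core.

Open, as far as these compounds go, is what a group other than the two halogen-bearing phenyl rings would do on the sulfonyl sulfur, for instance a phenyl carrying an amine or a carboxylic acid. Also open, from the compounds shown here alone, is whether full concentration-response data would separate these compounds, which a read-out at one concentration cannot do.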